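This account rests on a few compounds, and the source may have more. Where it says the series, first, only, none or still open, it means among the compounds named here.

Compound 1 `C[C@@H](c1cc2cccnc2cc1F)n1cnc2ncc(-c3cnn(C)c3)nc21`: 49 uL/min
Compound 2 `CNC(=O)c1ccc(-c2cnc3nnn(C(C)c4cc5cc(-c6cnn(C)c6)cnc5cc4F)c3n2)cc1F`: 12 uL/min

Both numbers come from an ADME assay on microsomes from liver (Rattus norvegicus) for metabolic stability, read by LC-MS, using NADPH, with stated times of 5 min and 30 min, tested at 1 uM; on this read-out higher numbers stand for fast clearance and lower numbers for slow clearance. Compound 2 stands lowest of the two values shown, and compound 1 sits well above it, a gap beyond the usual scatter. Compound 3 `CNC(=O)c1ccc(-c2cnc3nnn(C(C)c4c(F)cc5ncc(-c6cnn(C)c6)cc5c4F)c3n2)cc1F` differs from compound 2 by a single change: fluoro in place of hydrogen on an aromatic carbon. Among the compounds with values here, no measured pair of compounds isolates this change, so its effect is not known from the data at hand. The expected step, no change at the digits printed from compound 2 to compound 3 (within the scatter), is small and stays within the scatter. In this assay compound 3 is estimated at 12 uL/min, with a range from 5 uL/min to 28 uL/min.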

Compound 3, intrinsic clearance in a liver preparation (reported as CLH), per the amount of preparation that the assay uses: 48 uL/min
Estimate against measurement, compound 3: 4.0-fold (0.60 log units) below; measured number outside the range, above it.
By their numbers in this assay, from the lowest: compound 2; then compounds 3 and 1 (each within the scatter of the next).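

In this assay, the step of a 4.0-fold higher number from compound 2 to compound 3 (0.60 log units; beyond the scatter) comes with fluoro in place of hydrogen on an aromatic carbon, ortho to a fused ring and ortho to a large group. Within the data shown here, this is the first single change here that can be read on its own, and it shows that clearance responds to this one added atom at this position. Nothing at hand gives a reason for the step. Going by these compounds, whether chloro, methoxy or an amine on the same carbon would give a similar step stays open. So does whether fluoro here would act alike on the core of compound 1.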